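A few compounds are considered here, and "the series" means these few. Any claim that something is new, unique, unknown or untested is made for them only; others in the source may bear on it.

Of the compounds shown here, two of one series have been measured in an assay on CHO cells for displacement of a labelled ligand from adenosine receptor A3 (Homo sapiens), read by scintillation counting, tested at 10 uM; a lower number here means less inhibition, a higher number more inhibition at the concentration tested (going by the name of the read-out). Compound 1 `Cc1c(-c2ccccc2)sc(N)c1C(=O)c1ccc(Cl)cc1` gives 1% in this assay. Compound 2 `CC(C)(C)Cc1c(-c2cccc(F)c2F)sc(N)c1C(=O)c1ccc(Cl)cc1` gives 1% in this assay, and so compound 2 stands level with compound 1 at the digits shown: the two values lie within the scatter of each other, and no order between them can be read from them. Within the data shown here, no step between measured compounds that differ in one place is available, so there is no measured step from which the effect of exchanging a group on the shared core could be read.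

Compound 3 `CC(C)(C)Cc1c(-c2ccc(Cl)c(Cl)c2)sc(N)c1C(=O)c1ccc(Cl)cc1` differs from compound 2 in one place: 3,4-dichlorophenyl in place of 2,3-difluorophenyl on an aromatic carbon. Compound 1 with 1% and compound 2 with 1% both sit at the bottom of the read-out, and nothing in these two numbers points to a movement in either direction. The step from compound 2 to compound 3 is therefore expected to be none beyond the scatter, a number 1 percentage points higher from compound 2 to compound 3 (within the scatter). Compound 3 is expected to give 2%, with a range from -8% to 14%.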

Compound 3, a percentage reported as inhibition, at one concentration (the size of the read-out at that concentration, not a potency): 1%
Compound 3: the middle estimate sits 1 percentage points above what was measured, within the range that was stated.
By their numbers in this assay, from the lowest: compounds 1, 2 and 3 (each within the scatter of the next).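

In this assay, the exchange of 2,3-difluorophenyl for 3,4-dichlorophenyl, on the aromatic carbon next to the ring sulfur, gives no change at the digits printed from compound 2 to compound 3 (within the scatter). Among these compounds, this is the first measured step at this position, as the two earlier compounds differ in more than one place and offered no single exchange to read. It shows that, with the neopentyl group, the amino group and the (4-chlorophenyl)carbonyl group held in place, this change of one halogenated phenyl for another leaves the read-out at the concentration tested without a movement beyond the scatter, and nothing measured here bears on a reason for this result.

The compounds shown leave open whether any group on this aromatic carbon can move the read-out at all, since the one exchange measured here is between two phenyl rings carrying halogens, and a pyridine ring, a carboxylic acid or a morpholine at the same place would test a different kind of group. They also leave open whether replacing the neopentyl group with a longer chain, or the amino group with an acetamide, would change the inhibition in this assay on this shared core.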